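The source may report more compounds than this note shows. Statements on the series, on what has been measured and on what is new or still open speak of the compounds shown alone.

For the measured compounds named here, in a functional assay on HepG2 cells (Homo sapiens) for inhibition, read by MTT assay, with a stated time of 24 h (a lower number here means a stronger inhibitor of growth, a higher number a weaker inhibitor of growth), compound 2 (`Cn1cc(-c2nc3ccccc3n2C(=O)c2ccccc2)c2cc(Br)ccc21`) gives 48100 nM as the higher of the two numbers so far, and compound 1 (`COc1cccc(C(=O)n2c(-c3cn(C)c4ccccc34)nc3ccccc32)c1`) gives 13600 nM in the same test. The gap between these two numbers lies beyond the usual scatter. Compound 3 (`COc1cccc(C(=O)n2c(-c3cn(C)c4ccc(Br)cc34)nc3ccccc32)c1`) arises from compound 2 by one change (methoxy in place of hydrogen on an aromatic carbon), methoxy in place of hydrogen on an aromatic carbon, turning phenyl to 3-methoxyphenyl. Going by the values given here, no measured pair shows this change alone, so its size is uncertain. Compound 1 also carries a methoxy and gives the lower number (13600 nM), which points downward. The expected step is a moderate drop, just beyond the scatter (a 2.2-fold lower number from compound 2 to compound 3 (0.34 log units; beyond the scatter)). The estimated value for compound 3 is 22000 nM (range 9000 nM to 50000 nM).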

Compound 3, concentration for 50% growth inhibition: 17800 nM
For compound 3 the middle estimate is 1.2-fold (0.09 log units) above the measured one, within the range that was stated.
By their numbers in this assay, from the lowest: compounds 1 and 3 (each within the scatter of the next); then compound 2.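

In this assay, methoxy in place of hydrogen, turning phenyl to 3-methoxyphenyl, gives a 2.7-fold lower number from compound 2 to compound 3 (0.43 log units; beyond the scatter), the first direct sign that this ring position affects growth inhibition. With the methoxy in place, bromo in place of hydrogen gives a 1.3-fold higher number from compound 1 to compound 3 (0.12 log units; within the scatter), so this change shows no clear effect. Nothing measured here explains either step.

From the compounds shown here alone, whether bromo would also show no clear effect without the methoxy remains open. So does how an amine or a carboxylic acid at this position would compare with methoxy.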